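The source may hold more compounds than are shown below. What is called first, only, known or untested is meant among the compounds shown, and "the series" means these compounds.

Measured compounds:
compound 1 `COc1cccc(CNCCCNc2ccnc3cc(Oc4ccc(Cl)cc4)ccc23)c1O`: 9.28
compound 2 `COc1ccc(-c2ccc3c(NCCCNCc4ccco4)ccnc3c2)cc1`: 9.47

Both were measured in a physicochemical assay for acid dissociation. Compound 1 has the lower of the two numbers, but compound 2 lies within the usual scatter of it, so the two values show no real difference. Compound 3 `COc1cccc(CNCCCNc2ccnc3cc(Cc4cccc(C(F)(F)F)c4)ccc23)c1O` has not yet been measured. It differs from compound 1 in one place: 3-(trifluoromethyl)benzyl in place of 4-chlorophenoxy on an aromatic carbon. This change sits on the fused ring system of the shared core, far from the chain that carries the basic amine. A step from compound 1 to compound 3 of no size beyond the scatter is expected, in either direction, so the estimate is a number 0.02 log units higher from compound 1 to compound 3 (within the scatter). For compound 3 the value is estimated at 9.3, between 8.9 and 9.7.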

Compound 3, acid dissociation constant: 9.47
Compound 3: the middle estimate sits 0.17 log units below what was measured; measured number inside the range.
By their numbers in this assay, from the lowest: compounds 1, 2 and 3 (each within the scatter of the next).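

The measurement in this assay gives a number 0.19 log units higher from compound 1 to compound 3 (within the scatter) for 3-(trifluoromethyl)benzyl in place of 4-chlorophenoxy on this aromatic carbon. This single exchange swaps a group holding oxygen and chlorine, with one hydrogen-bond acceptor, for a group holding fluorine and no hydrogen-bond acceptor, yet it leaves no real difference in the read-out. No measured information on the reason for this result is available. As far as these compounds go, whether an amine or a carboxylic acid on this same carbon would give a step beyond the scatter stays open. From the compounds shown here alone, a longer chain at this carbon remains equally open.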